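Replacing bromo with methyl on compound 3

The source may report more compounds than this note shows. Statements on the series, on what has been measured and on what is new or still open speak of the compounds shown alone.

Measured so far:
- compound 1 `CCCC(CCC)C(=O)N(C)/N=N/c1ccc(C(=O)OCC)cc1`: 4.95
- compound 2 `CCCC(CCC)C(=O)N(C)/N=N/c1ccc(C(N)=O)cc1`: 3.68
- compound 3 `CCCC(CCC)C(=O)N(C)/N=N/c1ccc(Br)cc1`: 4.81

In a physicochemical assay for lipophilicity, read by HPLC, in phosphate buffer, measured as octanol-water partition, with stated times of 30 min and 48 h, at pH 7.4 (on this read-out higher numbers stand for higher lipophilicity and lower numbers for lower lipophilicity), compound 3 gives 4.81, within the scatter of compound 1 and clearly higher than compound 2. Compound 4 `CCCC(CCC)C(=O)N(C)/N=N/c1ccc(C)cc1` differs from it in one group: methyl in place of bromo on an aromatic carbon. Two measured steps also change the group on that aromatic carbon. Bromo in place of ethoxycarbonyl gave a number 0.14 log units lower from compound 1 to compound 3 (within the scatter), while bromo in place of carbamoyl gave a number 1.13 log units higher from compound 2 to compound 3 (beyond the scatter). Neither step involves methyl, so the evidence is indirect, and only a small downward step, not beyond the scatter, is expected in this assay. The estimated step is a number 0.21 log units lower from compound 3 to compound 4 (within the scatter). For compound 4, the expected value is 4.6, with an estimated range of 4.2 to 5.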

Compound 4, distribution coefficient: 4.98
For compound 4 the middle estimate is 0.38 log units below the measured one; low and high end bracket the measured number.
By their numbers in this assay, from the lowest: compound 2; then compounds 3, 1 and 4 (each within the scatter of the next).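

In this assay, methyl in place of bromo gives a small step (a number 0.17 log units higher from compound 3 to compound 4 (within the scatter)), and methyl in place of ethoxycarbonyl gives another (a number 0.03 log units higher from compound 1 to compound 4 (within the scatter)). Methyl, a plain carbon group, therefore cannot be told apart from bromo or ethoxycarbonyl at this position. Only carbamoyl stands apart, with methyl in its place giving a large step (a number 1.30 log units higher from compound 2 to compound 4 (beyond the scatter)). Still open, going by these compounds, is where an amine or a carboxylic acid on this aromatic carbon would fall in this assay. Nothing available explains why carbamoyl alone stands apart.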